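Swapping a hexyloxy chain for benzyloxy on a chalcone core

The source may hold more compounds than are shown below. What is called first, only, known or untested is meant among the compounds shown, and "the series" means these compounds.

Measured so far in a functional assay on PC-3 cells (Homo sapiens) for antiproliferative activity, read by sulforhodamine B assay; a higher number here means a weaker inhibitor of growth, a lower number a stronger inhibitor of growth:
- compound 1 `CCCCCCOc1cccc(O)c1C(=O)/C=C/c1ccc(O)cc1`: > 30000 nM
- compound 2 `CC(C)(C)CCOc1cccc(O)c1C(=O)/C=C/c1ccc(O)cc1`: 3220 nM
- compound 3 `O=C(/C=C/c1ccc(O)cc1)c1c(O)cccc1OCCC1CCCCC1`: > 30000 nM

Compound 1 gives only a limit of the assay, > 30000 nM, so its true value is not known. Compound 3 also sits at a limit, > 30000 nM. Among the measured compounds shown here, compound 2 is the only one with a number, 3220 nM.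

Compound 4 `O=C(/C=C/c1ccc(O)cc1)c1c(O)cccc1OCc1ccccc1` differs from compound 1 by phenyl in place of pentyl on a saturated chain carbon bound to an oxygen on an aromatic ring.

For the measured compounds named here, no measured step replaces a chain by an aromatic ring, so none bears directly on this change. The nearest guide is an at least 9.3-fold lower number from compound 1 to compound 2 (0.96 log units; beyond the scatter), which shows that shortening and branching the chain can move the number off the limit. The step that the two limits leave unreadable from compound 1 to compound 3 is unreadable because of the limit of > 30000 nM in this assay, at which 2 of the 3 values shown sit, and an at least 9.3-fold higher number from compound 2 to compound 3 (0.96 log units; beyond the scatter) shows that a bulkier ring on the chain loses that gain.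

For compound 4 the expected outcome is an improvement of uncertain size, estimated at 12000 nM, within 2500 nM to 40000 nM, meaning an expected step of an at least 2.5-fold lower number from compound 1 to compound 4 (0.39 log units; beyond the scatter).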

Compound 4, concentration for 50% growth inhibition: > 30000 nM
Compound 4 gave a limit, no number; the forecaster's own chance of this, stated with the estimate: 45%; middle value at least 2.5-fold (0.39 log units) away from the limit.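

Compound 4 sits at a limit of this assay, not at a number, so benzyloxy in place of hexyloxy brings no readable gain, and the steps to compound 4 from compound 1 and from compound 3 cannot be read for this reason: the limit of > 30000 nM in this assay, at which 3 of the 4 values shown sit.

Against compound 2, the only compound with a number, the change gives an at least 9.3-fold higher number from compound 2 to compound 4 (0.96 log units; beyond the scatter). Of the groups shown on this oxygen, only the neopentyl-bearing chain of compound 2 comes off the limit, while the straight chain of compound 1, the cyclohexyl ring of compound 3 and the phenyl ring of compound 4 all stay at it.

As far as these compounds go, the true values of compound 1, compound 3 and compound 4 remain unknown, so these three cannot be ranked. From the compounds shown here alone, whether a phenethyl chain or a chain ending in an amine would come off the limit also remains open.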